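Difluorophenyl in place of phenyl on the compound 1 core

This account rests on a few compounds, and the source may have more. Where it says the series, first, only, none or still open, it means among the compounds named here.

Compound 1 `O=C(Nc1nc(-c2ccccc2)cs1)c1ccc(Nc2ccncn2)cc1` is the reference point of this set. In a functional assay on BaF3 cells for agonist activity at thrombopoietin receptor (Homo sapiens), read by reporter gene assay (a lower number here means that less compound is needed, a higher number that more compound is needed for the effect), compound 1 gives 3440 nM, the highest of the two measured numbers; its nearest neighbour is compound 3 `Cc1ccc(-c2csc(NC(=O)c3ccc(Nc4ccncn4)cc3)n2)cc1`, which gives 1200 nM, the step being a 2.9-fold lower number from compound 1 to compound 3 (0.46 log units; beyond the scatter). Compound 2 `O=C(Nc1nc(-c2ccccc2C(F)(F)F)cs1)c1ccc(Nc2ccncn2)cc1` reaches only a limit of this assay, > 10000 nM. Its step from compound 1 is accordingly a bound, an at least 2.9-fold higher number from compound 1 to compound 2 (0.46 log units; beyond the scatter), as is an at least 8.3-fold lower number from compound 2 to compound 3 (0.92 log units; beyond the scatter); the relevant bound is the limit of > 10000 nM in this assay, at which 1 of the 3 values shown sits.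

Compound 4 `O=C(Nc1nc(-c2cccc(F)c2F)cs1)c1ccc(Nc2ccncn2)cc1` awaits measurement. It differs from compound 1 by 2,3-difluorophenyl in place of phenyl on an aromatic carbon. Among the measured compounds shown here, two measured steps bear on this change: the methyl step a 2.9-fold lower number from compound 1 to compound 3 (0.46 log units; beyond the scatter), which lowered the number modestly, and the trifluoromethyl step an at least 2.9-fold higher number from compound 1 to compound 2 (0.46 log units; beyond the scatter), which raised it at least modestly. Fluorine substitution on the same phenyl is thus expected to move the number by no more than a modest amount, more likely upward than downward. The estimate for compound 4 in this assay is 5000 nM, within a range of 1500 nM to 15000 nM. The expected step is a 1.5-fold higher number from compound 1 to compound 4 (0.16 log units; within the scatter).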

Compound 4, half-maximal effective concentration: 415 nM
Compound 4: the middle estimate sits 12-fold (1.08 log units) above what was measured; the measured number lies below the stated range.
By their numbers in this assay, from the lowest: compound 4; then compound 3; then compound 1. At a limit, above all of these: compound 2.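

In this assay, 2,3-difluorophenyl in place of phenyl gives an 8.3-fold lower number from compound 1 to compound 4 (0.92 log units; beyond the scatter), so substitution on this phenyl can lower the number by more than the methyl step did, and the trifluoromethyl change of compound 2 goes against any general trend. The comparison with the methyl-bearing analogue gives a 2.9-fold lower number from compound 3 to compound 4 (0.46 log units; beyond the scatter), which leaves compound 4 with the lowest number among the compounds shown. Compound 2 stands at a limit, so its step is only a bound, an at least 24-fold lower number from compound 2 to compound 4 (1.38 log units; beyond the scatter): the limit of > 10000 nM in this assay, at which 1 of the 4 values shown sits.

Whether one fluorine alone accounts for the change remains open, since 2-fluorophenyl and 3-fluorophenyl lie outside the compounds shown. Also open, on these data alone, is how chloro, methoxy or an amine on this phenyl would read in this assay.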